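This account rests on a few compounds, and the source may have more. Where it says the series, first, only, none or still open, it means among the compounds named here.

Among the compounds with values here, compound 2 `OCCCCCC(O)c1ccc(-c2ccc(F)cc2F)cc1` stands at the low end of the two numbers so far: in a functional assay on J774 cells (Mus musculus) for cytotoxicity, read by resazurin assay (on this read-out higher numbers stand for weaker inhibition and lower numbers for stronger inhibition), compound 2 gives 8000 nM. Within the data shown here, its nearest neighbour is compound 1 `OCCCCCC(O)c1ccc(-c2ccccc2F)cc1`, which in this assay gives 22000 nM, and the single measured step between them, a 2.8-fold lower number from compound 1 to compound 2 (0.44 log units; beyond the scatter), is the only guide this small set offers. Compound 3 `Cc1cc(F)ccc1-c1ccc(C(O)CCCCCO)cc1` differs from compound 2 by methyl in place of fluoro on an aromatic carbon. Among the measured compounds shown here, no measured step covers a methyl entering in place of a fluoro, so the step from compound 1 to compound 2, a fluoro entering in place of hydrogen, bears on compound 3 only loosely: it shows that a single-atom change at this part of the core moved the number modestly, and nothing more. The account therefore expects no step beyond the scatter for compound 3, allowing for a slight rise, a 1.5-fold higher number from compound 2 to compound 3 (0.18 log units; within the scatter), and estimates for compound 3 a value of 12000 nM in this assay, with a range from 5000 nM to 30000 nM.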

Compound 3, half-maximal inhibitory concentration: 20000 nM
Compound 3: the middle estimate sits 1.7-fold (0.22 log units) below what was measured; low and high end bracket the measured number.
By their numbers in this assay, from the lowest: compound 2; then compounds 3 and 1 (each within the scatter of the next).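

Within the data shown here, the step of a 2.5-fold higher number from compound 2 to compound 3 (0.40 log units; beyond the scatter) is the first measured change at the aromatic carbon ortho to a large group, and it shows that in this assay the number responds to what sits at this carbon, even when one heavy atom simply takes the place of another. It also runs the opposite way to a 2.8-fold lower number from compound 1 to compound 2 (0.44 log units; beyond the scatter), which took place on a different aromatic carbon, so the single-atom changes on this ring do not yet share one direction, though both steps are modest. Nothing measured here explains why the number rises when methyl replaces fluoro at this carbon.

The compounds shown leave open how a chloro, methoxy or trifluoromethyl group at this carbon would read, and so whether the rise is specific to methyl or would follow from any group replacing the fluoro here. They also leave open how far the number would move with changes away from this ring, such as a longer chain or a carboxylic acid on the shared core.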